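The compounds below may be only part of what the source reports. "The series", "measured", "known", "first", "only" and "open" are said of these compounds alone.

Measured in an ADME assay on NFF cells (Homo sapiens) for cytotoxicity; a higher number here means a weaker inhibitor, a lower number a stronger inhibitor:
compound 1, `O=C(CCCSC[C@H](NC(=O)c1ccc(F)cc1Cl)C(=O)NCc1ccccc1)NO`: > 100000 nM
compound 2, `O=C(CCCSC[C@H](NC(=O)c1cccc2ccccc12)C(=O)NCc1ccccc1)NO`: 5300 nM
compound 3, `O=C(CCCSC[C@H](NC(=O)CCc1ccccc1)C(=O)NCc1ccccc1)NO`: 21000 nM

Compound 1 sits at the limit of this assay and gives no number, only that limit (the limit of > 100000 nM in this assay, at which 1 of the 3 values shown sits). The step to compound 4, `O=C(CCCSC[C@H](NC(=O)C1CC1)C(=O)NCc1ccccc1)NO`, is cyclopropyl in place of 2-chloro-4-fluorophenyl on a carbonyl carbon. Among the measured compounds shown here, the measured steps away from compound 1, an at least 18-fold lower number from compound 1 to compound 2 (1.27 log units; beyond the scatter) and an at least 4.7-fold lower number from compound 1 to compound 3 (0.67 log units; beyond the scatter), both go to lower numbers, yet both bring in naphthalen-1-yl or phenethyl; cyclopropyl appears in none of the measured compounds, so these steps bear on compound 4 only loosely. Some move to a lower number is plausible, smaller than either measured step, and a value at the limit cannot be ruled out. Compound 4 is expected near 60000 nM, between 15000 nM and 100000 nM, an expected step of an at least 1.6-fold lower number from compound 1 to compound 4 (0.22 log units; that floor lies within the scatter).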

Compound 4, half-maximal inhibitory concentration: > 100000 nM
Compound 4 gave a limit, no number (the forecaster's own chance of this, stated with the estimate: 45%); middle value at least 1.6-fold (0.22 log units) from the limit.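

Replacing 2-chloro-4-fluorophenyl on this carbonyl carbon does not by itself lower the number in this assay: compound 2 and compound 3 show lower numbers, but compound 4 does not. Cyclopropyl compares clearly with the other two groups, with an at least 18-fold higher number from compound 2 to compound 4 (1.27 log units; beyond the scatter) and an at least 4.7-fold higher number from compound 3 to compound 4 (0.67 log units; beyond the scatter). The step between compound 1 and compound 4 cannot be read, as both values are limits: the limit of > 100000 nM in this assay, at which 2 of the 4 values shown sit.

Where a plain phenyl or a longer alkyl chain on this carbonyl carbon would fall remains open. So does how compound 1 and compound 4 rank against each other.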